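From 2-hydroxyethoxy to propargyloxy: a small step expected

A few compounds are considered here, and "the series" means these few. Any claim that something is new, unique, unknown or untested is made for them only; others in the source may bear on it.

Going by the values given here, in a functional assay on HL-60 cells (Homo sapiens) for cytotoxicity, read by MTT assay, with a stated time of 24 h (a lower number here means a stronger inhibitor, a higher number a weaker inhibitor), compound 1 (`BrCCCCCOc1c(Br)cc(Br)cc1Oc1ccc(Br)cc1Br`) gives 25.7 ug/mL and compound 2 (`OCCOc1c(Br)cc(Br)cc1Oc1ccc(Br)cc1Br`) gives 28.2 ug/mL, so compound 2 stands level with the only other measured compound. Among the compounds with values here, that comparison is also the only measured step, a 1.1-fold higher number from compound 1 to compound 2 (0.04 log units; within the scatter). It placed hydroxy in place of 3-bromopropyl on a saturated chain carbon, and so it altered the same chain that changes next.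

Compound 3 (`C#CCOc1c(Br)cc(Br)cc1Oc1ccc(Br)cc1Br`) keeps the shared core, and only the chain end differs: ethynyl in place of hydroxymethyl on a saturated chain carbon bound to an oxygen on an aromatic ring. In short, 2-hydroxyethyl gives way to propargyl.

Within the data shown here, no measured compound carries ethynyl, so this single step is thin evidence. Even so, it gives no reason to expect a change beyond the scatter in this assay. The expected move is a 1.1-fold lower number from compound 2 to compound 3 (0.05 log units; within the scatter). For compound 3, the estimated value is 25 ug/mL, within a range of 12 ug/mL to 48 ug/mL.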

Compound 3, half-maximal inhibitory concentration: 29.7 ug/mL
Estimate against measurement, compound 3: 1.2-fold (0.07 log units) below, within the range that was stated.
By their numbers in this assay, from the lowest: compounds 1, 2 and 3 (each within the scatter of the next).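

In this assay the move to ethynyl in place of hydroxymethyl gives a 1.1-fold higher number from compound 2 to compound 3 (0.02 log units; within the scatter) and so shows that this chain end can carry a triple bond and lose its 1 hydrogen-bond donor and 1 hydrogen-bond acceptor without a change beyond the scatter. The further comparison gives a 1.2-fold higher number from compound 1 to compound 3 (0.06 log units; within the scatter) for ethynyl in place of 4-bromobutyl, so three quite different chain ends now stand level on the shared core. No measured evidence explains why these chain ends stand level in this read-out.

As far as these compounds go, whether this tolerance extends to a chain ending in an amine or a carboxylic acid remains open. So does the question of whether a phenyl ring at the chain end would also leave the number within the scatter.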